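Series notes: the amide aryl group in this assay

The source may report more compounds than this note shows. Statements on the series, on what has been measured and on what is new or still open speak of the compounds shown alone.

The shared core of compound 1 `O=C(Nc1ccc(Cl)c(-c2nnc3c(Cl)cccn23)c1)c1ccc(C(F)(F)F)cc1F` carries an amide whose aryl group is varied. In a functional assay on MCF7 cells (Homo sapiens) for antiproliferative activity, read by MTT assay, with a stated time of 72 h (on this read-out higher numbers stand for weaker inhibition and lower numbers for stronger inhibition), compound 1 gives 62800 nM. Compound 2 `O=C(Nc1ccc(Cl)c(-c2nnc3c(Cl)cccn23)c1)c1ccccc1Cl` gives 92200 nM in this assay, the highest of the two numbers that stand as plain values; the nearest is compound 1, and the two lie within the scatter of each other. Compound 3 `O=C(Nc1ccc(Cl)c(-c2nnc3c(Cl)cccn23)c1)c1ccc(F)cc1Cl` reaches only the limit of this assay, > 100000 nM. Among the compounds with values here, the one step that can be counted, an at least 1.0-fold higher number from compound 2 to compound 3 (0.03 log units; that floor lies within the scatter), is a fluoro in place of hydrogen on an aromatic carbon and, since it rests on a limit (the limit of > 100000 nM in this assay, at which 1 of the 3 values shown sits), shows no more than a floor that lies within the scatter.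

Compound 4 `O=C(Nc1ccc(Cl)c(-c2nnc3c(Cl)cccn23)c1)c1cccnc1Cl` differs from compound 2 by 2-chloropyridin-3-yl in place of 2-chlorophenyl on a carbonyl carbon. Within the data shown here, no measured step changes the ring of the aroyl group itself, so only the general level of the series bears on the expectation: all three values sit near or beyond the limit of this assay. For compound 4 no step beyond the scatter is expected, a 1.0-fold lower number from compound 2 to compound 4 (0.01 log units; within the scatter). Compound 4 is therefore estimated at 90000 nM, with a range from 35000 nM to 250000 nM.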

Compound 4, half-maximal inhibitory concentration: > 100000 nM
Compound 4: a limit, no number (the forecaster's own chance of this, stated with the estimate: 45%); middle value at least 1.1-fold (0.04 log units) from the limit.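

Within the data shown here, the change from 2-chlorophenyl to 2-chloropyridin-3-yl on a carbonyl carbon is the first measured change to the ring of the aroyl group itself, and in this assay it gives an at least 1.0-fold higher number from compound 2 to compound 4 (0.03 log units; that floor lies within the scatter). This result gives no sign that the entering ring nitrogen, counted as a hydrogen-bond acceptor, brings stronger inhibition, but it cannot set the size of any loss, and the step from compound 3 to compound 4 cannot be read because both values are limits. The value of compound 4 is itself a limit and not a number, which adds to the weight of limits in this small set: the limit of > 100000 nM in this assay, at which 2 of the 4 values shown sit.

Among these compounds, compound 1 and compound 2 remain the only plain values and lie within the scatter of each other, so it remains open whether any change to the amide aryl group can move this series clearly away from the limit. Also open, from the compounds shown here alone, is how the shared core behaves with a different group on the carbonyl carbon, such as a piperidine, an aminophenyl group or a benzoic acid.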